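Notes on the step from compound 2 to compound 3

The compounds below may be only part of what the source reports. "The series", "measured", "known", "first", "only" and "open" are said of these compounds alone.

In an ADME assay on A549 cells (Homo sapiens) for cytotoxicity, read by resazurin assay, with a stated time of 48 h (a lower number here means that less compound is tolerated, a higher number that more compound is tolerated), compound 1 (`CC(C)Nc1ccc(NC(=O)c2cc(Cl)ccc2O)c(Cl)c1`) gives 11000 nM and compound 2 (`O=C(Nc1ccc(NCc2ccc(C(F)(F)F)cc2)cc1Cl)c1cc(Cl)ccc1O`) gives 62700 nM, the higher of the two numbers and beyond the scatter. Compound 3 (`O=C(Nc1ccc(NCc2cc(F)cc(Cl)c2)cc1Cl)c1cc(Cl)ccc1O`) carries 3-chloro-5-fluorophenyl in place of 4-(trifluoromethyl)phenyl on a saturated chain carbon bound to a nitrogen on an aromatic ring, with 3-chloro-5-fluorophenyl in place of 4-(trifluoromethyl)phenyl on a saturated chain carbon bound to a nitrogen on an aromatic ring. Among the compounds with values here, no measured pair differs in one place, so the data offer no direct guide. A lower number is expected in this assay, since compound 2 at 62700 nM is the top of the two measured numbers. The expected change is a 2.1-fold lower number from compound 2 to compound 3 (0.32 log units; beyond the scatter), a modest fall. For compound 3 the estimated value is 30000 nM, with an expected range of 11000 nM to 70000 nM.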

Compound 3, half-maximal cytotoxic concentration: 11100 nM
The estimate for compound 3 lay 2.7-fold (0.43 log units) above the measured number, and the stated range covers the measured number.
By their numbers in this assay, from the lowest: compounds 1 and 3 (each within the scatter of the next); then compound 2.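

In this assay the group on a saturated chain carbon bound to a nitrogen on an aromatic ring matters: 3-chloro-5-fluorophenyl in place of 4-(trifluoromethyl)phenyl gives a 5.6-fold lower number from compound 2 to compound 3 (0.75 log units; beyond the scatter) at this position. With 3-chloro-5-fluorobenzyl in place of isopropyl on that nitrogen the series shows a 1.0-fold higher number from compound 1 to compound 3 (0.00 log units; within the scatter) so a benzyl group there does not by itself give a higher number. No measurement on hand accounts for either step.

On these data alone, whether the higher number of compound 2 belongs to the trifluoromethyl group or to its place on the ring stays open. As far as these compounds go, how an amine or a carboxylic acid on this ring would read also remains unknown.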